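A few compounds are considered here, and "the series" means these few. Any claim that something is new, unique, unknown or untested is made for them only; others in the source may bear on it.

Two members of this series have numbers in a functional assay on MCF7 cells (Homo sapiens) for cytotoxicity, read by MTT assay; on this read-out higher numbers stand for weaker inhibition and lower numbers for stronger inhibition. Compound 1 `c1ccc(Cc2nnc(-c3c[nH]c4ccccc34)o2)cc1` gives 39200 nM in this assay, and compound 2 `COc1cc(-c2nnc(-c3cn(C)c4ccccc34)o2)ccc1OCc1ccccc1` gives 35200 nM. Of the two numbers, that of compound 1 is the higher, but the gap to compound 2 lies within the scatter of this assay, so the two stand together as weak inhibitors, and no order between them can be read from these values.

Compound 3 `FC(F)(F)c1nnc(-c2c[nH]c3ccccc23)o1` is the next compound awaiting this assay. Compared with compound 1 it carries trifluoromethyl in place of benzyl on an aromatic carbon. Within the data shown here, no comparable change has been measured, so there is no step from which to read its effect. Given the weak level of compound 1 at 39200 nM, the expected step of a 1.1-fold higher number from compound 1 to compound 3 (0.03 log units; within the scatter) is none beyond the scatter, in either direction. Compound 3 is estimated at 42000 nM in this assay, with a range from 15000 nM to 110000 nM.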

Compound 3, half-maximal inhibitory concentration: > 1000000 nM
Compound 3 gave a limit, no number; the forecaster's own chance of this, stated with the estimate: 25%; middle value at least 23-fold (1.37 log units) away from the limit.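

Trifluoromethyl in place of benzyl on an aromatic carbon of the five-membered aromatic ring gives an at least 25-fold higher number from compound 1 to compound 3 (1.40 log units; beyond the scatter), the first step in the series beyond the scatter, so the group at this position does matter, even starting from the weak level of compound 1. In this assay compound 3 gives only a limit, not a number: > 1000000 nM. The size of the step rests on that limit and not on a measured value for compound 3: the limit of > 1000000 nM in this assay, at which 1 of the 3 values shown sits.

This single change removes the benzyl group and its ring and brings in trifluoromethyl, so the compounds shown do not tell whether the shift comes from what leaves or from what enters. A simple methyl, a longer carbon chain, an amine or a phenyl at the same position would help separate these two readings.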